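Swapping Phenyl for Methoxy on a Sulfonamide Core

The source may hold more compounds than are shown below. What is called first, only, known or untested is meant among the compounds shown, and "the series" means these compounds.

Compound 3 `O=S(=O)(NCCCNCc1ccc(-c2ccccc2)cc1)c1cc(C(F)(F)F)cc(C(F)(F)F)c1` gives the lowest number of the three measured compounds in a functional assay on PANC-1 cells (Homo sapiens) for inhibition, read by MTT assay, with a stated time of 72 h (on this read-out higher numbers stand for weaker inhibition of growth and lower numbers for stronger inhibition of growth), with 2500 nM. Compound 2 `O=S(=O)(NCCCNCc1cccc(Cl)c1)c1cc(C(F)(F)F)cc(C(F)(F)F)c1` gives 12000 nM, and compound 1 `COc1ccc(CNCCCNS(=O)(=O)c2cc(C(F)(F)F)cc(C(F)(F)F)c2)cc1OC` gives 18000 nM. Among the measured compounds shown here, the one measured single-place step, a 1.5-fold lower number from compound 1 to compound 2 (0.18 log units; within the scatter), lies within the scatter. Compound 4 `COc1ccc(CNCCCNS(=O)(=O)c2cc(C(F)(F)F)cc(C(F)(F)F)c2)cc1` differs from compound 3 by methoxy in place of phenyl on an aromatic carbon. For the measured compounds named here, no measured step covers this change directly; the nearest hint is that compounds 1 and 2, which lack the phenyl, both stand well above compound 3. A weaker result than compound 3 is therefore expected, with an estimated step of a 4.0-fold higher number from compound 3 to compound 4 (0.60 log units; beyond the scatter). Compound 4 is estimated at 10000 nM, within a range from 4000 nM to 25000 nM.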

Compound 4, concentration for 50% growth inhibition: 11000 nM
The estimate for compound 4 lay 1.1-fold (0.04 log units) below the measured number, and the stated range covers the measured number.
By their numbers in this assay, from the lowest: compound 3; then compounds 4, 2 and 1 (each within the scatter of the next).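

Methoxy in place of phenyl on this aromatic carbon gives a 4.4-fold higher number from compound 3 to compound 4 (0.64 log units; beyond the scatter) in this assay, so the earlier hint about the phenyl now rests on a direct pair. The other changes stay within the scatter: a 1.1-fold lower number from compound 2 to compound 4 (0.04 log units; within the scatter) for 4-methoxyphenyl in place of 3-chlorophenyl and a 1.6-fold lower number from compound 1 to compound 4 (0.21 log units; within the scatter) for hydrogen in place of methoxy. Nothing here accounts for the difference between phenyl and methoxy. Still open, from the compounds shown here alone, is whether a pyridine ring or a cyclohexyl ring on this carbon would match phenyl, and what a longer chain in the shared core would do.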